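A chloro step on compound 3

The compounds below may be only part of what the source reports. "The series", "measured", "known", "first", "only" and "open" are said of these compounds alone.

Measured so far in a functional assay on MDA-MB-231 cells (Homo sapiens) for inhibition, with a stated time of 48 h (a higher number here means a weaker inhibitor of growth, a lower number a stronger inhibitor of growth), are three compounds
Compound 1 `COc1ccccc1/C=C/C(=O)c1c(O)cc2occc2c1OC` gives 33100 nM
Compound 2 `COc1c(C(=O)/C=C/c2ccc(Cl)cc2)c(O)c(Br)c2occc12` gives 4330 nM
Compound 3 `C=CCc1c(O)c(C(=O)/C=C/c2ccccc2)c(OC)c2ccoc12` gives 3110 nM

Compound 3 at 3110 nM stands level with compound 2 within the scatter, while compound 1 at 33100 nM lies beyond the scatter from it on the weaker side. Compound 4 `C=CCc1c(O)c(C(=O)/C=C/c2ccc(Cl)cc2)c(OC)c2ccoc12` differs from compound 3 by chloro in place of hydrogen on an aromatic carbon with chloro in place of hydrogen on an aromatic carbon, turning phenyl to 4-chlorophenyl. Among the measured compounds shown here, no measured pair isolates this change. Compound 2 also carries a 4-chlorophenyl, though it differs elsewhere too, and at 4330 nM it gives only a loose hint. The expected 1.1-fold lower number from compound 3 to compound 4 (0.05 log units; within the scatter) stays within the scatter in this assay with no firm direction. Compound 4 is estimated at 2800 nM with an expected range from 1100 nM to 7000 nM in this measure.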

Compound 4, concentration for 50% growth inhibition: 4300 nM
Compound 4: middle estimate off by 1.5-fold (0.19 log units), on the low side; the range from low to high includes it.
By their numbers in this assay, from the lowest: compounds 3, 4 and 2 (each within the scatter of the next); then compound 1.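

In this assay, among the compounds shown here, chloro in place of hydrogen on the aromatic carbon, para to a large group, gives a 1.4-fold higher number from compound 3 to compound 4 (0.14 log units; within the scatter), the first direct reading at this position, and it shows that phenyl and 4-chlorophenyl cannot be told apart here. With 4-chlorophenyl held in place, allyl in place of bromo on an aromatic carbon gives a 1.0-fold lower number from compound 2 to compound 4 (0.00 log units; within the scatter), so that swap also stays within the scatter. Nothing shown here explains either result. From the compounds shown here alone, whether an amine or a carboxylic acid at the chloro position, or a longer chain in place of allyl, would give a step beyond the scatter remains open.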